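The source may report more compounds than this note shows. Statements on the series, on what has been measured and on what is new or still open speak of the compounds shown alone.

Measured in a physicochemical assay for permeability, using PAMPA; a lower number here means that the compound crosses the layer more slowly, a higher number that the compound crosses the layer faster:
- compound 1 `O=C(O)CCn1c(=O)oc2cc(OCc3ccccn3)c(Cl)cc21` gives 11 nm/s
- compound 2 `COc1cc2oc(=O)n(CCC(=O)O)c2cc1Cl` gives < 3 nm/s, a limit of the assay and not a number

Compound 2 therefore has no exact place on the scale. Compound 3 `CCOc1cc2oc(=O)n(CCC(=O)O)c2cc1Cl` has methyl in place of hydrogen on a saturated chain carbon bound to an oxygen on an aromatic ring, turning methoxy into ethoxy. Among the measured compounds shown here, the only measured step at this place is an at least 3.6-fold lower number from compound 1 to compound 2 (0.56 log units; beyond the scatter), and it involves pyridin-2-yl, a far larger group than methyl. A small rise at most is therefore expected in this assay, and it may not exceed the scatter. The expected step is an at least 1.1-fold higher number from compound 2 to compound 3 (0.06 log units; that floor lies within the scatter). For compound 3 the estimate is 3.5 nm/s, with an expected range of 1.5 nm/s to 8 nm/s.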

Compound 3, apparent permeability: < 10 nm/s
Compound 3 ended at the assay's limit; the forecaster's own chance of this, stated with the estimate: 50%; the middle value is on the limit's open side.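

In this assay, the change from methoxy to ethoxy gives no size: compound 2 and compound 3 both carry limits of the assay and not numbers, so the step between them cannot be read. Methyl in place of pyridin-2-yl gives an at least 1.1-fold lower number from compound 1 to compound 3 (0.04 log units; that floor lies within the scatter). Unlike the step to compound 2, this one therefore does not show a loss beyond the scatter, though the true drop could be larger.

Where compound 2 and compound 3 truly lie remains open. So does whether a longer chain, such as propyl, or an amine on this saturated chain carbon would give a measurable number.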